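The source may report more compounds than this note shows. Statements on the series, on what has been measured and on what is new or still open speak of the compounds shown alone.

Compound 2 `O=C(CC1c2ccccc2N=C(SCCCCCN2CCCC2)N1c1ccc(-c2ccc(F)cc2)cc1)NCc1ccc(F)cc1` gives 76.6% in an assay on cells for inhibition of Voltage-dependent T-type calcium channel subunit alpha-1H (Homo sapiens), read by patch clamp, tested at 10 uM (a lower number here means less inhibition, a higher number more inhibition at the concentration tested (going by the name of the read-out)), and stands second highest of the three numbers measured: compound 1 `O=C(CC1c2ccccc2N=C(SCCCCCN2CCCC2)N1c1ccc(-c2ccccc2)cc1)NCc1ccc(F)cc1` gives 69% and compound 3 `O=C(CC1c2ccccc2N=C(SCCCCCN2CCCC2)N1c1ccc(-c2ccc(F)cc2)cc1)NCc1ccccc1` gives 97.5%. The step of a number 7.6 percentage points higher from compound 1 to compound 2 (within the scatter) remains within the scatter, whereas the step of a number 20.9 percentage points higher from compound 2 to compound 3 (beyond the scatter) goes beyond it. Compound 4 `O=C(CC1c2ccccc2N=C(SCCCCCN2CCCC2)N1c1ccccc1)NCc1ccc(F)cc1` carries hydrogen in place of 4-fluorophenyl on an aromatic carbon. Going by the values given here, no measured step removes this ring: the nearest comparison, from compound 1 to compound 2, only alters the same ring and stayed within the scatter, while the larger step from compound 2 to compound 3 concerns a different part of the molecule. The expected step of a number 18.6 percentage points lower from compound 2 to compound 4 (beyond the scatter) is therefore uncertain and leans downward. Compound 4 is estimated at 58%, in a range from 30% to 85%.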

Compound 4, a percentage reported as inhibition, at one concentration (the size of the read-out at that concentration, not a potency): 40%
Estimate against measurement, compound 4: 18 percentage points above; the measured number falls inside the stated range.
By their numbers in this assay, from the lowest: compound 4; then compounds 1 and 2 (each within the scatter of the next); then compound 3.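

Replacing the outer ring at this position matters far more in this assay than changing it: hydrogen in place of 4-fluorophenyl gives a number 36.6 percentage points lower from compound 2 to compound 4 (beyond the scatter) and hydrogen in place of phenyl gives a number 29 percentage points lower from compound 1 to compound 4 (beyond the scatter), whereas adding fluoro to that ring stayed within the scatter. Among these three compounds, the ring itself, not its fluoro, accounts for the difference. No available data give a reason for this drop.

Still open, going by these compounds, is whether a smaller group here, such as methoxy or chlorine, or a pyridine ring in place of the outer ring, would retain the inhibition. Also open, on these data alone, is whether the loss would recur with the unsubstituted benzyl amide of compound 3.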